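The source may hold more compounds than are shown below. What is called first, only, known or untested is meant among the compounds shown, and "the series" means these compounds.

Measured compounds, with their values in an ADME assay on microsomes from liver (Rattus norvegicus) for metabolic stability, read by LC-MS, tested at 0.5 uM; on this read-out lower numbers stand for a shorter-lived compound and higher numbers for a longer-lived compound:

compound 1 `Cc1cc(CCOc2ccc(-c3c(C)nc(C)c([C@H](OC(C)(C)C)C(=O)O)c3N3CCC(C)(C)CC3)cc2)ccc1F` — > 2 h, a limit of the assay
compound 2 `Cc1nc(C)c([C@H](OC(C)(C)C)C(=O)O)c(N2CCC(C)(C)CC2)c1-c1ccc(SCCc2ccc(F)cc2)cc1` — > 2 h, a limit of the assay
compound 3 `Cc1nc(C)c([C@H](OC(C)(C)C)C(=O)O)c(N2CCC(C)(C)CC2)c1-c1ccc(OC2COCC2c2ccc(F)cc2)cc1` — > 2 h, a limit of the assay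

Compound 3 therefore stands at the upper limit of this assay , which is also where every other measured value in the series sits (the limit of > 2 h in this assay, at which 3 of the 3 values shown sit). Among the compounds with values here, no compound yet gives a read number.

The next compound, compound 4 `Cc1ccc(CCOc2ccc(-c3c(C)nc(C)c([C@H](OC(C)(C)C)C(=O)O)c3N3CCC(C)(C)CC3)cc2)s1`, differs from compound 3 in one place: 2-(5-methylthiophen-2-yl)ethyl in place of 4-(4-fluorophenyl)oxolan-3-yl on an oxygen on an aromatic ring.

Two measured steps change the same region of the core. The step that the two limits leave unreadable from compound 1 to compound 2 and the step that the two limits leave unreadable from compound 1 to compound 3 are both unreadable, since both ends lie at the limit. Neither step can say how far above the limit any compound really sits, nor whether the group on the aromatic oxygen moves the half-life at all. The change to compound 4 is of the same kind and at the same position, so the working expectation is a step of no readable size, most likely with compound 4 again reported only as a limit.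

Compound 4 is thus estimated at 2.5 h, with a range from 1 h to 6 h. The step this estimate implies is a step that the limit leaves unreadable from compound 3 to compound 4, expected to stay within the scatter.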

Compound 4, half-life: > 2 h
Compound 4: only a limit was reported; the forecaster's own chance of this, stated with the estimate: 70%; the middle value does not contradict the limit.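

In this assay compound 4 gives > 2 h, a limit of the assay. Its steps from compound 1, compound 2 and compound 3 cannot be read, since both ends of each step are limits: the limit of > 2 h in this assay, at which 4 of the 4 values shown sit. The compounds shown leave open how long any of them actually lasts and whether these group changes move the half-life at all.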